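A few compounds are considered here, and "the series" means these few. Any claim that something is new, unique, unknown or untested is made for them only; others in the source may bear on it.

Measured so far in a functional assay on CHO cells for agonist activity at metabotropic glutamate receptor 5 (Homo sapiens), read by inositol phosphate accumulation; on this read-out higher numbers stand for weaker inhibition and lower numbers for stronger inhibition:

- compound 1 `Nc1nc(C#Cc2cccnc2)cs1`: 789 nM
- compound 2 `Cc1nc(C#Cc2ccc(OS(C)(=O)=O)nc2)cs1`: 2340 nM
- compound 3 `Cc1nc(C#Cc2ccc(-c3ccc(F)cc3)nc2)cs1`: 10.2 nM

Compound 3 gives the lowest number of the three in this assay, and its gaps to compound 1 and to compound 2 both lie beyond the scatter. Among the measured compounds shown here, only one single-point step is available within the set: a 230-fold lower number from compound 2 to compound 3 (2.36 log units; beyond the scatter), where 4-fluorophenyl replaced (methylsulfonyl)oxy on the aromatic carbon of the pyridine-type ring. That step shows the aromatic carbon in question to be a position at which the identity of the substituent moves the read-out by a large amount.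

Compound 4 `C=Cc1ccc(C#Cc2csc(C)n2)cn1` is the next variation at the same position: vinyl in place of 4-fluorophenyl on an aromatic carbon. The 4-fluorophenyl that accompanied the low number of compound 3 is replaced by a two-carbon vinyl group. For the measured compounds named here, no measured pair shows a small substituent at this position other than compound 2, so the expectation rests on the size of the step from compound 2 to compound 3 and on the removal of the ring that accompanied it. A step upward in this assay is expected for compound 4, of roughly a 39-fold higher number from compound 3 to compound 4 (1.59 log units; beyond the scatter), well beyond the scatter though short of the full reversal seen with (methylsulfonyl)oxy. The expected value for compound 4 is 400 nM, with a range of 60 nM to 3000 nM.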

Compound 4, half-maximal inhibitory concentration: > 10000 nM
Compound 4 was reported as a limit; the forecaster's own chance of this, stated with the estimate: 5%; middle value at least 25-fold (1.39 log units) from the limit.
By their numbers in this assay, from the lowest: compound 3; then compound 1; then compound 2. At a limit, above all of these: compound 4.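

In this assay, compound 4 is reported only as a limit and not as a number: the limit of > 10000 nM in this assay, at which 1 of the 4 values shown sits. Vinyl in place of 4-fluorophenyl gives an at least 980-fold higher number from compound 3 to compound 4 (2.99 log units; beyond the scatter), so at this aromatic carbon the low number of compound 3 does not persist once the six-membered aromatic ring of carbon is replaced by this two-carbon group. Vinyl in place of (methylsulfonyl)oxy gives an at least 4.2-fold higher number from compound 2 to compound 4 (0.63 log units; beyond the scatter), which adds what the earlier step could not show: exchanging (methylsulfonyl)oxy for a carbon-linked group does not by itself bring a low number, and among the three groups compared here only 4-fluorophenyl does.

The compounds shown leave open whether the low number depends on the aromatic ring itself or on the fluorine it carries, a question that plain phenyl, a 4-methoxyphenyl group or a saturated cyclohexyl ring at the same carbon would address. They also leave open where between vinyl and 4-fluorophenyl the read-out recovers, for which cyclopropyl, a longer chain such as butyl, or an amine such as morpholine would give intermediate cases.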